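Working notes on a weak-binding nitro sulfone amide series

This account rests on a few compounds, and the source may have more. Where it says the series, first, only, none or still open, it means among the compounds named here.

Measured so far:
compound 1 `CS(=O)(=O)c1ccc(C(=O)N2CCC(C(=O)N3CCc4ccccc4C3)CC2)cc1[N+](=O)[O-]`: > 60000 nM
compound 2 `CC1CCN(C(=O)CCCNC(=O)c2ccc(S(C)(=O)=O)c([N+](=O)[O-])c2)CC1`: > 60000 nM

In an assay on isolated protein for inhibition of thyroid hormone receptor alpha (Homo sapiens), read by fluorescence polarization (on this read-out higher numbers stand for weaker inhibition and lower numbers for stronger inhibition), compound 1 gives > 60000 nM, which is a limit of the assay and not a number. Compound 2 also reaches only a limit, > 60000 nM. Compound 1 therefore stands nowhere in particular among the numbers shown: both values sit at the limit of > 60000 nM in this assay, at which 2 of the 2 values shown sit, so no step between measured compounds can be sized, and no direction of change is known in this series.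

Compound 3 `CC1Cc2ccccc2N1C(=O)C1CCN(C(=O)c2ccc(S(C)(=O)=O)c([N+](=O)[O-])c2)CC1` has not been measured. It differs from compound 1 by 2-methyl-2,3-dihydro-1H-indol-1-yl in place of 1,2,3,4-tetrahydroisoquinolin-2-yl on a carbonyl carbon. With both measured compounds at the limit, the expected step is a number no higher from compound 1 to compound 3 (the limit leaves the size open), none beyond the scatter, and the reading will most likely again be a limit rather than a number. Compound 3 is expected near 60000 nM, with a range from 20000 nM to 200000 nM.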

Compound 3, half-maximal inhibitory concentration: > 60000 nM
Compound 3: a limit, no number; the forecaster's own chance of this, stated with the estimate: 80%; the middle value lies on the limit itself.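

Going by these compounds alone, compound 1 and compound 3 both stand at a limit of the assay and not at a number, so no step between them can be read: the limit of > 60000 nM in this assay, at which 3 of the 3 values shown sit.

The compounds shown leave open whether any change to the shared core gives a number in this assay.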